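The source may hold more compounds than are shown below. What is called first, only, known or untested is meant among the compounds shown, and "the series" means these compounds.

Measured compounds and their values:
Compound 1 `O=C(CCc1ccccc1)NCC(=O)NC(c1ccccc1)c1ccc(Cl)cc1`: 4790 nM
Compound 2 `N#Cc1ccc(C(=O)NCC(=O)NC(c2ccccc2)c2ccc(Cl)cc2)cc1`: 230 nM

Going by the values given here, in an assay for inhibition of sodium- and chloride-dependent glycine transporter 1 (Homo sapiens) (a lower number here means that less compound is needed, a higher number that more compound is needed for the effect), compound 2 stands at the lower of the two numbers, and its nearest neighbour is compound 1; the single measured step, a 21-fold lower number from compound 1 to compound 2 (1.32 log units; beyond the scatter), separates them clearly. Compound 3 `O=C(CNC(=O)c1ccsc1)NC(c1ccccc1)c1ccc(Cl)cc1` differs from compound 2 by thiophen-3-yl in place of 4-cyanophenyl on a carbonyl carbon. That one step bears on this change only in part: it shows that an aromatic ring set directly on the carbonyl carbon, carrying a nitrile, gave a far lower number than a phenethyl chain. Compound 3 keeps an aromatic ring on that carbon but loses the nitrile and swaps the six-membered ring for a five-membered one. Among the compounds with values here, no measured pair separates these two parts of the change, so the expectation is a moderate rise in the number, an estimated step of a 3.5-fold higher number from compound 2 to compound 3 (0.54 log units; beyond the scatter). For compound 3 the estimated value is 800 nM, with an expected range from 250 nM to 2500 nM.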

Compound 3, half-maximal effective concentration: 89 nM
The estimate for compound 3 lay 9.0-fold (0.95 log units) above the measured number; the whole stated range lies above it.
By their numbers in this assay, from the lowest: compound 3; then compound 2; then compound 1.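

In this assay, the nitrile is not needed for a low number at this position on the carbonyl carbon: thiophen-3-yl, a smaller group by heavy atoms than 4-cyanophenyl, gives a 2.6-fold lower number from compound 2 to compound 3 (0.41 log units; beyond the scatter). Going by these compounds alone, the earlier compounds showed only one aromatic ring on this carbon, and thiophen-3-yl now shows that a five-membered aromatic ring with sulfur also does far better than the phenethyl chain, with a 54-fold lower number from compound 1 to compound 3 (1.73 log units; beyond the scatter). The low number at this position therefore does not depend on 4-cyanophenyl alone.

The compounds shown do not separate the loss of the nitrile from the change of ring, and an unsubstituted phenyl or a furan-3-yl group on the same carbonyl carbon would bear on that question. Nothing available gives a reason for the difference between thiophen-3-yl and 4-cyanophenyl.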